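Chloro on the phenoxy arm of compound 1

The source may hold more compounds than are shown below. What is called first, only, known or untested is meant among the compounds shown, and "the series" means these compounds.

Compound 1 `NC1=NC2(CCOCC2)N(OCCCOc2ccccc2)C(N)=N1` carries an unsubstituted phenyl on the oxygen of the saturated chain. In an assay on isolated protein for inhibition of Dihydrofolate reductase (Homo sapiens), read by spectrophotometry, using NADPH, with stated times of 5 s and 6 min, tested at 5 uM (a lower number here means a weaker effect, a higher number a stronger effect of the compound at the concentration tested), compound 1 gives > 90%, which is a limit of the assay rather than a number. Compound 1 therefore sits at the ceiling (the limit of > 90% in this assay, at which 1 of the 3 values shown sits), and only a range is known for it. Compound 2 `NC1=NC2(CCOCC2)N(OCCCOc2cccc(Cl)c2Cl)C(N)=N1`, with 2,3-dichlorophenyl in place of phenyl on an oxygen on a saturated carbon, gives 81.7% in this assay. Compound 3 `NC1=NC2(CCSCC2)N(OCCCOc2cc(Cl)c(Cl)cc2Cl)C(N)=N1`, which differs from the others also in the shared core, gives 84.4% in this assay. For the measured compounds named here, the one measured step that bears on the present change is a number at least 8.3 percentage points lower from compound 1 to compound 2 (that floor lies within the scatter); its floor lies within the scatter, so that substitution may have cost little or nothing.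

Compound 4 `NC1=NC2(CCOCC2)N(OCCCOc2cccc(Cl)c2)C(N)=N1` differs from compound 1 as follows: chloro in place of hydrogen on an aromatic carbon. This is a lesser version of the change in the measured step, so a step in this assay no larger than that one is expected, downward if at all, and quite possibly within the scatter. The expected step from compound 1 is a number at least 2 percentage points lower from compound 1 to compound 4 (that floor lies within the scatter). Compound 4 is accordingly estimated at 88% in this assay, within 78% to 95%.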

Compound 4, a percentage reported as inhibition, at one concentration (the size of the read-out at that concentration, not a potency): 83.2%
For compound 4 the middle estimate is 4.8 percentage points above the measured one; the measured number falls inside the stated range.
By their numbers in this assay, from the lowest: compounds 2, 4 and 3 (each within the scatter of the next). At a limit, above all of these: compound 1.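

In this assay the change from phenyl to 3-chlorophenyl gives a number at least 6.8 percentage points lower from compound 1 to compound 4 (that floor lies within the scatter), so a single chloro on this aromatic carbon, like the dichloro change before it, shows no loss that can be separated from noise. The new comparison is with the dichloro arm: a number 1.5 percentage points higher from compound 2 to compound 4 (within the scatter), so the 3-chlorophenyl and 2,3-dichlorophenyl arms of compound 4 and compound 2 cannot be told apart in this read-out, and the extra chloro has no visible effect here. The true size of the step from the unsubstituted phenyl stays unknown because the value of compound 1 is a limit of the assay and not a number: the limit of > 90% in this assay, at which 1 of the 4 values shown sits.

As far as these compounds go, whether chloro on the phenoxy arm lowers inhibition at all remains open, and a read-out at a single concentration cannot settle that for compound 1 and compound 4. Also open, from the compounds shown here alone, is how far this aromatic carbon accepts groups other than chloro, such as an amine or a carboxylic acid, and how the series responds to a longer chain in the arm.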